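The source may hold more compounds than are shown below. What is called first, only, known or untested is meant among the compounds shown, and "the series" means these compounds.

Compound 1 `N#Cc1cc2c(nc1N1CCC(C(=O)NS(=O)(=O)C(F)(F)c3ccccc3)CC1)COC2=O` stands without a single number in a functional assay (Platelet, plasma) for inhibition, with Homo sapiens as the target; a lower number here means a stronger inhibitor, a higher number a weaker inhibitor: compound 1 gives "not determined" (no result reported) there. Within the data shown here, the one measured member of the series, compound 2 `CC1(C(=O)NS(=O)(=O)Cc2ccc(Cl)cc2)CCN(c2nc3c(cc2C#N)C(=O)OC3)CC1`, gives 3010 nM in this assay. Compound 3 `CC(c1ccccc1)S(=O)(=O)NC(=O)C1CCN(c2nc3c(cc2C#N)C(=O)OC3)CC1` differs from compound 1 in one place (1-phenylethyl in place of difluoro(phenyl)methyl on a sulfonyl sulfur). Among the measured compounds shown here, with no result for compound 1 and no step between measured compounds in this assay, neither size nor direction of the change can be read from the series; at most a modest shift, possibly none beyond the scatter, is expected. Compound 3 is expected to give about 2000 nM, estimated within 500 nM to 8000 nM.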

Compound 3, half-maximal inhibitory concentration: 4160 nM
For compound 3 the middle estimate is 2.1-fold (0.32 log units) below the measured one; the measured number falls inside the stated range.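

Among these compounds, no step between compound 1 and compound 3 can be read in this assay, where compound 1 gives "not determined" (no result reported). Going by these compounds, the effect of exchanging difluoro(phenyl)methyl for 1-phenylethyl on the sulfonyl sulfur remains open. No supporting data bear on this result.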